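The source may hold more compounds than are shown below. What is called first, only, known or untested is meant among the compounds shown, and "the series" means these compounds.

Measured so far in a physicochemical assay for lipophilicity, measured as octanol-water partition; on this read-out higher numbers stand for higher lipophilicity and lower numbers for lower lipophilicity:
- compound 1 `O=C(NNc1ccnc2cc(Cl)ccc12)c1ccccc1/N=C/c1ccc(F)cc1`: 5.18
- compound 2 `O=C(NNc1ccnc2cc(Cl)ccc12)c1ccccc1/N=C/c1ccccc1Cl`: 5.5

Going by the values given here, compound 2 holds the higher of the two numbers, at 5.5, and no measured compound stands above it. Compound 3 `O=C(NNc1ccnc2cc(Cl)ccc12)c1ccccc1/N=C/c1ccc(Cl)c(Cl)c1` is not yet measured. It carries 3,4-dichlorophenyl in place of 2-chlorophenyl on a carbon with a double bond to nitrogen. Among the compounds with values here, one measured step bears on this change, as it concerns the same place: a number 0.32 log units higher from compound 1 to compound 2 (beyond the scatter). That step is modest but beyond the scatter. Within the data shown here, no measured pair shows this exact exchange, so the guide is thin. An upward move in this assay, of modest size or somewhat more, is expected: a number 0.50 log units higher from compound 2 to compound 3 (beyond the scatter). For compound 3 the estimated value is 6, with an expected range of 5.6 to 6.4.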

Compound 3, partition coefficient: 6.22
The estimate for compound 3 lay 0.22 log units below the measured number, and the stated range covers the measured number.
By their numbers in this assay, from the lowest: compound 1; then compound 2; then compound 3.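

In this assay, the position on a carbon with a double bond to nitrogen responds further to the aryl group: 3,4-dichlorophenyl in place of 2-chlorophenyl gives a number 0.72 log units higher from compound 2 to compound 3 (beyond the scatter) and so extends the series upward. Against 4-fluorophenyl the same group gives a number 1.04 log units higher from compound 1 to compound 3 (beyond the scatter) and thus opens a large span at this one position, where the earlier step was only modest. No measurement at hand offers an explanation for either step.

The exchange from 2-chlorophenyl to 3,4-dichlorophenyl alters both the number of chlorine atoms and where they sit, so the compounds shown do not separate these two changes. All three groups are halogen-bearing phenyl rings, which leaves open how this position would respond to a phenyl ring carrying an amine or a carboxylic acid.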